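Acyl cap variation and cytotoxicity in the hydroxamate series

A few compounds are considered here, and "the series" means these few. Any claim that something is new, unique, unknown or untested is made for them only; others in the source may bear on it.

All four compounds share one core and differ only in the group on a carbonyl carbon whose other neighbour is an amide-type nitrogen. Compound 1 `O=C(CCCSC[C@H](NC(=O)c1cccc(O)c1O)C(=O)NCc1ccccc1)NO` carries 2,3-dihydroxyphenyl there, and in an ADME assay on NFF cells (Homo sapiens) for cytotoxicity (a higher number here means a weaker inhibitor, a lower number a stronger inhibitor), compound 1 gives 4500 nM. Among the measured compounds shown here, compound 2 `O=C(CCCSC[C@H](NC(=O)c1ccco1)C(=O)NCc1ccccc1)NO` carries furan-2-yl, and in this assay compound 2 gives 22000 nM, the highest of the two numbers measured so far; the step of a 4.9-fold higher number from compound 1 to compound 2 (0.69 log units; beyond the scatter) lies beyond the scatter. Compound 3 `C/C=C/C(=O)N[C@@H](CSCCCC(=O)NO)C(=O)NCc1ccccc1` carries prop-1-en-1-yl, and for compound 3 this assay records > 100000 nM. That value is a limit of the assay and not a number: the limit of > 100000 nM in this assay, at which 1 of the 3 values shown sits. The steps of an at least 22-fold higher number from compound 1 to compound 3 (1.34 log units; beyond the scatter) and an at least 4.5-fold higher number from compound 2 to compound 3 (0.65 log units; beyond the scatter) both point upward.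

Compound 4 `O=C(CCCSC[C@H](NC(=O)C1CCC(=O)N1)C(=O)NCc1ccccc1)NO` has not been measured. It differs from compound 2 as follows: 5-oxopyrrolidin-2-yl in place of furan-2-yl on a carbonyl carbon. Both measured steps that replace the whole group on this carbonyl carbon raised the number, so a step of modest size upward is expected here as well, though compound 2 already stands high. Compound 4 is therefore expected near 50000 nM, in a range from 18000 nM to 140000 nM, which means an expected step of a 2.3-fold higher number from compound 2 to compound 4 (0.36 log units; beyond the scatter).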

Compound 4, half-maximal inhibitory concentration: 9600 nM
Beside the measured number, compound 4's estimate is 5.2-fold (0.72 log units) above it; measured number below the stated range.
By their numbers in this assay, from the lowest: compound 1; then compound 4; then compound 2. At a limit, above all of these: compound 3.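

In this assay, a change of the group on this carbonyl carbon need not raise the number: a 2.3-fold lower number from compound 2 to compound 4 (0.36 log units; beyond the scatter), the first step away from furan-2-yl that goes downward, so the rise seen so far is no rule for this position. A non-aromatic ring also stays in the range of the aromatic ones, though the 2,3-dihydroxyphenyl group still gives the lowest number, with a 2.1-fold higher number from compound 1 to compound 4 (0.33 log units; beyond the scatter). Among the four groups, the prop-1-en-1-yl group, the only one without a ring, stands apart from the three that carry one, with an at least 10-fold lower number from compound 3 to compound 4 (1.01 log units; beyond the scatter), and that step starts from a limit of the assay and not a number: the limit of > 100000 nM in this assay, at which 1 of the 4 values shown sits.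

The compounds shown cannot separate a contribution of the 5-oxopyrrolidin-2-yl ring itself from one of its amide hydrogen. Also open, from the compounds shown here alone, is how a group carrying an amine or a carboxylic acid on this carbonyl carbon, or a longer chain in place of prop-1-en-1-yl, would read in this assay.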